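Replacing the ester of compound 1 with a nitrile

This account rests on a few compounds, and the source may have more. Where it says the series, first, only, none or still open, it means among the compounds named here.

Compound 1 `CCOC(=O)/C=C/C1=CC[C@H]2C(C)(C)CCC[C@]2(C)[C@H]1C=O`: 29000 nM
Compound 2 `CCOC(=O)/C(C)=C/C1=CC[C@H]2C(C)(C)CCC[C@]2(C)[C@H]1C=O`: 37000 nM
Compound 3 `CC1(C)CCC[C@]2(C)[C@@H](C=O)C(/C=C/C(=O)OCc3ccccc3)=CC[C@@H]12`: 39000 nM

These three compounds were tested in a functional assay on SK-MEL-28 cells (Homo sapiens) for inhibition, read by MTT assay, with a stated time of 72 h; a higher number here means a weaker inhibitor of growth, a lower number a stronger inhibitor of growth. Compound 1 stands level with the other two, since the three values lie within the scatter of one another and none can be set apart from the rest.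

The compound still to be measured is compound 4 `CC1(C)CCC[C@]2(C)[C@@H](C=O)C(/C=C/C#N)=CC[C@@H]12`. It keeps the core of compound 1 but carries cyano in place of ethoxycarbonyl on a double-bonded chain carbon bound to a double-bonded chain carbon.

Among the measured compounds shown here, only one measured step bears on this change, and only indirectly. It is a 1.3-fold higher number from compound 1 to compound 3 (0.13 log units; within the scatter), where phenyl takes the place of methyl on a saturated chain carbon bound to an oxygen next to a carbonyl group. That step alters the far end of the ester and leaves the carbonyl group in place. For the measured compounds named here, no measured compound lacks the ester, so the data do not test its loss directly, and the range must stay wide.

With nothing pointing either way, the step expected in this assay is a 1.0-fold higher number from compound 1 to compound 4 (0.01 log units; within the scatter), which would be none beyond the scatter.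

For compound 4 the estimated value is 30000 nM, with an expected range of 13000 nM to 70000 nM.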

Compound 4, concentration for 50% growth inhibition: 42000 nM
Compound 4: the middle estimate sits 1.4-fold (0.15 log units) below what was measured; low and high end bracket the measured number.
By their numbers in this assay, from the lowest: compounds 1, 2, 3 and 4 (each within the scatter of the next).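

In this assay, putting cyano in place of ethoxycarbonyl on a double-bonded chain carbon bound to a double-bonded chain carbon gives a 1.4-fold higher number from compound 1 to compound 4 (0.16 log units; within the scatter). Among the compounds shown here, this is the first measured step at this position that removes the ester altogether, whereas the earlier step altered only its far end and kept the carbonyl; here 2-(ethoxycarbonyl)ethenyl gives way to 2-cyanoethenyl, a group of 5 heavy atoms to one of 2, and the triple bond takes the place of the carbonyl, yet the two compounds cannot be told apart, so the ester is not required for the level of growth inhibition seen with compound 1. No measurement is available that explains why the ester and the nitrile read alike in these cells.

From the compounds shown here alone, whether an amide, a carboxylic acid or a primary alcohol on the same chain would also stay level with compound 1 remains open, as does the effect of a longer chain between the core and the nitrile. The aldehyde on the shared core is also present in every compound shown, so what happens when it gives way to a hydroxymethyl group or a carboxylic acid is equally unanswered.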